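The source may hold more compounds than are shown below. What is called first, only, known or untested is meant among the compounds shown, and "the series" means these compounds.

Measured in a functional assay on PC-3 cells (Homo sapiens) for antiproliferative activity, read by MTT assay, with a stated time of 72 h; on this read-out higher numbers stand for weaker inhibition and lower numbers for stronger inhibition:
- Compound 1 `O=C(N/N=C/c1ccc([N+](=O)[O-])cc1)Nc1ccc(Oc2ccnc3[nH]ccc23)cc1`: 28100 nM
- Compound 2 `COc1ccc(/C=N/NC(=O)Nc2ccc(Oc3ccnc4[nH]ccc34)cc2)cc1`: "not active" (no number reported)
- Compound 3 `CN(C)CCCn1cccc1/C=N/NC(=O)Nc1ccc(Oc2ccnc3[nH]ccc23)cc1`: 5150 nM

Compound 3 holds the lower of the two numbers in this assay, while compound 2 gave no number. The next analogue, compound 4 `O=C(N/N=C/c1cccn1CCCN1CCCC1)Nc1ccc(Oc2ccnc3[nH]ccc23)cc1`, changes only the amine at the end of the chain: pyrrolidin-1-yl in place of dimethylamino on a saturated chain carbon, three bonds along the chain from an aromatic nitrogen. Going by the values given here, only one measured step bears on this, and only indirectly. It is a 5.5-fold lower number from compound 1 to compound 3 (0.74 log units; beyond the scatter), a modest step beyond the scatter, in which 1-(3-(dimethylamino)propyl)-1H-pyrrol-2-yl replaced 4-nitrophenyl. That step exchanged the whole group carrying the chain, so it does not isolate the contribution of the amine. Among the compounds with values here, no measured pair changes the dimethylamino group alone. A much smaller change than that step is therefore expected in this assay, with no step beyond the scatter in either direction. The expected step is a 1.0-fold lower number from compound 3 to compound 4 (0.01 log units; within the scatter). For compound 4 the estimated value is 5000 nM, with an expected range from 2200 nM to 12000 nM.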

Compound 4, half-maximal inhibitory concentration: 4290 nM
The estimate for compound 4 lay 1.2-fold (0.07 log units) above the measured number, within the range that was stated.
By their numbers in this assay, from the lowest: compounds 4 and 3 (each within the scatter of the next); then compound 1.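

In this assay, going by these compounds alone, the amine at the end of the chain is changed on its own for the first time, and the result is a 1.2-fold lower number from compound 3 to compound 4 (0.08 log units; within the scatter). The earlier step replaced the whole group carrying the chain, whereas this one shows that on a saturated chain carbon, three bonds along the chain from an aromatic nitrogen, pyrrolidin-1-yl can stand in place of dimethylamino with no change that this read-out can resolve. Thus, for these two amines, the added five-membered non-aromatic ring leaves the number within the scatter, and no supporting data are available to explain this result.

Only these two amines are compared, so the compounds shown leave open how a piperidin-1-yl or morpholin-4-yl group would read at this place. They also leave open whether a longer chain, or a carboxylic acid in place of the amine, would keep the number of compound 4 4290 nM.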